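A few compounds are considered here, and "the series" means these few. Any claim that something is new, unique, unknown or untested is made for them only; others in the source may bear on it.

Compound 1 `CCCCCCCCCCCCNC(=O)[C@@H](NC(=O)c1ccccc1)[C@@H](C)O`, compound 2 `CCCCCCCCCCCCNC(=O)[C@@H](NC(=O)c1ccco1)[C@@H](C)O`, compound 3 `CCCCCCCCCCCCCCCCCCNC(=O)[C@@H](NC(=O)c1ccccc1)[C@@H](C)O` and the still unmeasured compound 4 `CCCCCCCCCCCCCCCCCCNC(=O)[C@@H](NC(=O)c1ccco1)[C@@H](C)O` share one core in which only the acyl ring and the chain length change. In a functional assay on HepG2 cells (Homo sapiens) for cytotoxicity, read by MTT assay, with a stated time of 48 h (a lower number here means a stronger inhibitor, a higher number a weaker inhibitor), compound 1 gives only a limit, > 400000 nM. In this assay compound 2 gives 147000 nM. In this assay compound 3 likewise gives only a limit, > 400000 nM. The cores of compound 1 and compound 3 differ by hexyl in place of hydrogen on a saturated chain carbon, ten or more bonds along the chain from an amide-type nitrogen, and the step is a step that the two limits leave unreadable from compound 1 to compound 3; both values sit at the limit of > 400000 nM in this assay, at which 2 of the 3 values shown sit. The change furan-2-yl in place of phenyl on a carbonyl carbon produced an at least 2.7-fold lower number from compound 1 to compound 2 (0.43 log units; beyond the scatter). The same change, (furan-2-yl in place of phenyl on a carbonyl carbon), turns compound 3 into compound 4. He expects a step of an at least 1.6-fold lower number from compound 3 to compound 4 (0.20 log units; that floor lies within the scatter), resting on the earlier at least 2.7-fold lower number from compound 1 to compound 2 (0.43 log units; beyond the scatter). For compound 4 he estimates 250000 nM, expected between 120000 nM and 400000 nM.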

Compound 4, half-maximal inhibitory concentration: 42300 nM
The estimate for compound 4 lay 5.9-fold (0.77 log units) above the measured number; measured number below the stated range.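

In this assay, furan-2-yl in place of phenyl on a carbonyl carbon gave an at least 9.4-fold lower number from compound 3 to compound 4 (0.97 log units; beyond the scatter), so the change lowered the number on both cores shown. With furan-2-yl kept in place, hexyl in place of hydrogen on the chain gave a 3.5-fold lower number from compound 2 to compound 4 (0.54 log units; beyond the scatter). The two pairs therefore agree in direction, but they do not show that the size of the step carries from one core to the other: the same change on two cores in this assay, an at least 2.7-fold lower number (0.43 log units; beyond the scatter) from compound 1 to compound 2 and an at least 9.4-fold lower number (0.97 log units; beyond the scatter) from compound 3 to compound 4; the limit leaves it open whether they differ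

The compounds shown leave open whether a longer chain than that of compound 4 would lower the number further. They also leave open how a carboxylic acid or an amine in place of the furan-2-yl group would read in this assay.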